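The source may report more compounds than this note shows. Statements on the series, on what has been measured and on what is new or still open speak of the compounds shown alone.

Measured so far:
compound 1, `O=C1CC(c2ccccc2OCc2ccc(F)cc2)Oc2ccccc21`: 50.5%
compound 2, `CC(C)c1ccc(COc2ccccc2C2CC(=O)c3ccccc3O2)cc1`: 32.3%

In a functional assay on the whole organism (strain Sprague-Dawley) for inhibition, with Rattus norvegicus as the target, read by paw edema, with stated times of 1 h and 5 h, at a dose of 150 umol/kg by the oral route (a higher number here means more inhibition at the dose given (going by the name of the read-out), a lower number less inhibition), compound 2 gives 32.3%, the lower of the two numbers, while compound 1 gives 50.5%. Within the data shown here, the single measured step, a number 18.2 percentage points lower from compound 1 to compound 2 (beyond the scatter), consists of isopropyl in place of fluoro on an aromatic carbon. Compound 3, `O=C1CC(c2ccccc2OCc2ccccc2)Oc2ccccc21`, has not yet been measured; it differs from compound 2 by hydrogen in place of isopropyl on an aromatic carbon. Among the measured compounds shown here, the only measured step that bears on this change is the one from compound 1 to compound 2, which was modest and beyond the scatter; there isopropyl entered and the number fell. The present step takes the isopropyl away again, so a rise of roughly the same size is expected, a number 12.7 percentage points higher from compound 2 to compound 3 (beyond the scatter). The estimate for compound 3 in this assay is therefore 45%, within a range from 30% to 60%.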

Compound 3, a percentage reported as inhibition, in the whole organism at one dose (the size of the read-out at that dose, not a potency): 35.7%
Estimate against measurement, compound 3: 9.3 percentage points above; the measured number falls inside the stated range.
By their numbers in this assay, from the lowest: compounds 2 and 3 (each within the scatter of the next); then compound 1.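

In this assay, taking the isopropyl away does not restore the number: a number 3.4 percentage points higher from compound 2 to compound 3 (within the scatter), so at this place on the aromatic ring, hydrogen and isopropyl cannot be told apart. Fluoro at the same place stands apart from hydrogen, with a number 14.8 percentage points lower from compound 1 to compound 3 (beyond the scatter), so the difference seen earlier between the fluoro and isopropyl compounds lies with fluoro, and isopropyl shows no lowering of its own relative to hydrogen. No measurement shown offers an explanation for this difference.

The compounds shown leave open whether chloro, methoxy or an amine at this place would group with fluoro or with hydrogen and isopropyl. They also leave open whether the same grouping would hold at another dose in this assay.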